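Swapping the pyridyl arm for furan in a thiazole acetic acid

The compounds below may be only part of what the source reports. "The series", "measured", "known", "first", "only" and "open" are said of these compounds alone.

Of the compounds shown here, three of a shared core have been tested in an in vitro functional assay on HEK285-7 cells for antagonist activity at prostaglandin D2 receptor 2 (Homo sapiens), read by BRET and beta-arrestin recruitment; on this read-out lower numbers stand for stronger inhibition and higher numbers for weaker inhibition. Compound 1 `O=C(O)Cc1sc(COc2ccc(Cl)cc2)nc1-c1ccc(Cl)cc1` gives 370 nM. Compound 2 `O=C(O)Cc1sc(C(c2ccc(F)cc2)c2ccc(F)cc2)nc1-c1ccnc(N2CCC2)c1` gives only a limit of the assay, > 100000 nM. Compound 3 `O=C(O)Cc1sc(C(c2ccccc2)c2ccccc2)nc1-c1ccc(C(F)(F)F)cc1` likewise gives only a limit of the assay, > 100000 nM. Compound 2 therefore stands at the limit of > 100000 nM in this assay, at which 2 of the 3 values shown sit, with no number of its own, while compound 1 is the only one of the three with a measured value.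

Compound 4 `O=C(O)Cc1sc(C(c2ccc(F)cc2)c2ccc(F)cc2)nc1-c1ccoc1` is the next compound to be measured in this assay. It differs from compound 2 in one place: furan-3-yl in place of 2-(azetidin-1-yl)pyridin-4-yl on an aromatic carbon. Going by the values given here, no step between measured compounds is available to show what such a change does, and compound 3, which shares the doubly aryl-substituted methyl group with compound 2, also sits at the limit. Compound 4 is therefore expected to stay weak, with an estimated step of an at least 1.4-fold lower number from compound 2 to compound 4 (0.15 log units; that floor lies within the scatter) that is not expected to be beyond the scatter. The estimate for compound 4 in this assay is 70000 nM, with a range from 7000 nM to 500000 nM, and a limit rather than a number is considered more likely than not.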

Compound 4, half-maximal inhibitory concentration: 130 nM
The estimate for compound 4 lay 540-fold (2.73 log units) above the measured number; the measured number lies below the stated range.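

In this assay, the aromatic carbon next to the ring nitrogen proves decisive for compounds carrying the doubly aryl-substituted methyl group: furan-3-yl in place of 2-(azetidin-1-yl)pyridin-4-yl gives an at least 760-fold lower number from compound 2 to compound 4 (2.88 log units; beyond the scatter). That group therefore does not by itself hold a compound at the limit, as compound 2 and compound 3 together might have suggested. The step is only a floor, since compound 2 has a limit of the assay and no number of its own: the limit of > 100000 nM in this assay, at which 2 of the 4 values shown sit.

The swap removes the azetidine, the pyridine ring and its nitrogen in one change, so the compounds shown cannot tell which of these matters. They also leave open how a plain pyridin-4-yl, a thiophen-3-yl or a furan-2-yl would read at this position.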